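This account rests on a few compounds, and the source may have more. Where it says the series, first, only, none or still open, it means among the compounds named here.

Compound 1 `FC(F)(F)c1cccc(-c2nnnn2CCCN2CCC(Cc3ccccc3)CC2)c1` and compound 2 `Clc1cccc(-c2nnnn2CCCN2CCC(Cc3ccccc3)CC2)c1Cl` share the same core and differ only in the aromatic group attached to it. In an assay on HEK293 cells for inhibition of sodium-dependent dopamine transporter (Homo sapiens), read by scintillation counting (on this read-out lower numbers stand for stronger inhibition and higher numbers for weaker inhibition), compound 1 gives 3740 nM. Compound 2 reaches only the limit of this assay, > 10000 nM, so for compound 2 a limit and not a number is known. As far as these compounds go, the step of an at least 2.6-fold higher number from compound 1 to compound 2 (0.42 log units; beyond the scatter) is therefore bounded by the limit of > 10000 nM in this assay, at which 1 of the 2 values shown sits, and the true size of that step is unknown. Compound 3 `c1ccc(CC2CCN(CCCn3nnnc3-c3cccc4ccccc34)CC2)cc1` carries naphthalen-1-yl in place of 2,3-dichlorophenyl on an aromatic carbon. Going by the values given here, no measured step covers this exchange; the only step that bears on this position is an at least 2.6-fold higher number from compound 1 to compound 2 (0.42 log units; beyond the scatter), which shows that changing the aryl group can move the number by at least a modest amount in this assay. Compound 3 is expected to give about 6000 nM, within a range of 1500 nM to 25000 nM. This estimate corresponds to an expected step of an at least 1.6-fold lower number from compound 2 to compound 3 (0.22 log units; that floor lies within the scatter).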

Compound 3, half-maximal inhibitory concentration: 6000 nM
Estimate against measurement, compound 3: no gap at the digits printed, and the stated range covers the measured number.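

In this assay, naphthalen-1-yl in place of 3-(trifluoromethyl)phenyl gives a 1.6-fold higher number from compound 1 to compound 3 (0.21 log units; within the scatter), so a second six-membered aromatic ring at this position leaves the two compounds indistinguishable. Compound 2 sits at a limit of the assay, > 10000 nM, and not at a number, whereas naphthalen-1-yl, the largest of the three groups by heavy atoms, still gives a measurable value. Naphthalen-1-yl in place of 2,3-dichlorophenyl gives an at least 1.6-fold lower number from compound 2 to compound 3 (0.22 log units; that floor lies within the scatter), and this step cannot be read in size: the limit of > 10000 nM in this assay, at which 1 of the 3 values shown sits.

The compounds shown leave open how far the true number of compound 2 lies from those of compound 1 and compound 3. They also leave open how an aryl group carrying an amine or a carboxylic acid, or a pyridine ring in this place, would read in this assay.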